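Compound 3 to compound 4: methylsulfonyl for trifluoromethyl

The compounds below may be only part of what the source reports. "The series", "measured", "known", "first", "only" and "open" are said of these compounds alone.

Measured compounds, each value a limit of the assay:
- compound 1 `CCOC(=O)c1c(-c2cccc(OCC(C)C)c2)[nH]c2cc(OC)ccc2c1=O` gives > 21500 nM
- compound 2 `CCOC(=O)c1c(-c2cccc(OCc3ccccc3)c2)[nH]c2cc(OC)ccc2c1=O` gives > 21500 nM
- compound 3 `CCOC(=O)c1c(-c2cccc(C(F)(F)F)c2)[nH]c2cc(OC)ccc2c1=O` gives > 21500 nM

In an ADME assay on HepG2 cells (Homo sapiens) for cytotoxicity, read by luminescence, with a stated time of 72 h (on this read-out lower numbers stand for an effect already at smaller amounts and higher numbers for an effect only at larger amounts of compound), compound 3 gives > 21500 nM, which is a limit and not a number. The series as a whole stands at the limit of > 21500 nM in this assay, at which 3 of the 3 values shown sit, so compound 3 has no readable position relative to compound 1 or compound 2.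

Compound 4 `CCOC(=O)c1c(-c2cccc(S(C)(=O)=O)c2)[nH]c2cc(OC)ccc2c1=O` carries methylsulfonyl in place of trifluoromethyl on an aromatic carbon, meta to a large group (methylsulfonyl in place of trifluoromethyl on an aromatic carbon). The nearest measured changes are at this same place: a step that the two limits leave unreadable from compound 1 to compound 3 and a step that the two limits leave unreadable from compound 2 to compound 3. Neither gives a size that can be carried over, and the same holds for a step that the two limits leave unreadable from compound 1 to compound 2.

Within the data shown here, what they do show is that isobutoxy, benzyloxy and trifluoromethyl all leave the read-out at the limit, and no measured compound goes against this. A further limit is therefore the likely outcome in this assay, with no direction expected. The estimate means a step that the limit leaves unreadable from compound 3 to compound 4, which is expected to lie within the scatter. For compound 4 the estimated value is 25000 nM, with an expected range from 12000 nM to 50000 nM.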

Compound 4, half-maximal effective concentration: > 21500 nM
Compound 4: no number, only a limit (the forecaster's own chance of this, stated with the estimate: 90%); the middle value is on the limit's open side.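

In this assay compound 4 gives > 21500 nM, which is a limit. The steps to compound 4 from compound 1, compound 2 and compound 3 therefore cannot be read, and the series offers only this: the limit of > 21500 nM in this assay, at which 4 of the 4 values shown sit.

The compounds shown leave open whether any group at this place on the shared core gives a readable value in this assay, and how large any difference between these groups would be.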